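A few compounds are considered here, and "the series" means these few. Any claim that something is new, unique, unknown or untested is made for them only; others in the source may bear on it.

Values in a functional assay on the whole organism (strain Sprague-Dawley) for inhibition, with Rattus norvegicus as the target, with a stated time of 10 min; on this read-out lower numbers stand for an effect already at smaller amounts and higher numbers for an effect only at larger amounts of compound:
compound 1 `O=C(O)c1cnc(-c2ccccc2)[nH]c1=O`: 50 mg/kg
compound 2 `O=C(O)c1cnc(-c2ccccc2[N+](=O)[O-])[nH]c1=O`: > 50 mg/kg (a limit)
compound 3 `CCOc1ccccc1-c1ncc(C(=O)O)c(=O)[nH]1`: 0.5 mg/kg

Compound 2 shows > 50 mg/kg here, which is a limit and not a number. Compound 4 `CCCCOc1ccccc1-c1ncc(C(=O)O)c(=O)[nH]1` carries butoxy in place of nitro on an aromatic carbon, ortho to a large group: butoxy in place of nitro on an aromatic carbon. Among the measured compounds shown here, no measured compound carries butoxy, so the nearest guide is ethoxy in compound 3. Ethoxy in place of nitro gave an at least 100-fold lower number from compound 2 to compound 3 (2.00 log units; beyond the scatter), and ethoxy in place of hydrogen gave a 100-fold lower number from compound 1 to compound 3 (2.00 log units; beyond the scatter). Both steps are large. As far as these compounds go, the size of a number no lower from compound 1 to compound 2 (the limit leaves the size open) stays open. A large step toward a lower number is therefore expected, estimated as an at least 50-fold lower number from compound 2 to compound 4 (1.69 log units; beyond the scatter). Compound 4 is expected at 1 mg/kg, with an estimated range from 0.2 mg/kg to 5 mg/kg.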

Compound 4, dose for 50% inhibition: 0.5 mg/kg
For compound 4 the middle estimate is 2.0-fold (0.30 log units) above the measured one; the measured number falls inside the stated range.
By their numbers in this assay, from the lowest: compounds 3 and 4 (each within the scatter of the next); then compound 1.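

Butoxy on an aromatic carbon ortho to a large group gives a large step, a 100-fold lower number from compound 1 to compound 4 (2.00 log units; beyond the scatter), so the gain is not confined to ethoxy. The longer chain shows no change at the digits printed from compound 3 to compound 4 (within the scatter), and against nitro the step is an at least 100-fold lower number from compound 2 to compound 4 (2.00 log units; beyond the scatter). That last step starts from a limit for compound 2: the limit of > 50 mg/kg in this assay, at which 1 of the 4 values shown sits.

As far as these compounds go, whether a chain longer than butoxy would hold this level remains open. So does the outcome with an amine or a carboxylic acid on this aromatic carbon.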